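Swapping the benzyl substituent: nitro out, ethoxy in

The source may hold more compounds than are shown below. What is called first, only, known or untested is meant among the compounds shown, and "the series" means these compounds.

Measured so far, all in a functional assay on thoracic aorta for antagonist activity at Alpha-1D adrenergic receptor (Rattus norvegicus); a higher number here means a more potent compound, by a factor of ten per unit of this negative logarithm, a lower number a less potent compound:
compound 1 `COc1cccc(OC)c1OCCNCCOc1ccccc1OCc1ccc(Cl)cc1` gives 9.11
compound 2 `COc1cccc(OC)c1OCCNCCOc1ccccc1OCc1ccc(C)cc1` gives 9.12
compound 3 `COc1cccc(OC)c1OCCNCCOc1ccccc1OCc1cccc([N+](=O)[O-])c1` gives 9.28

Compound 3 shows the largest of these three figures, but the gaps a number 0.17 log units higher from compound 1 to compound 3 (within the scatter) and a number 0.16 log units higher from compound 2 to compound 3 (within the scatter) both lie within the scatter, so the three compounds are effectively indistinguishable in this assay.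

Compound 4 `CCOc1ccc(COc2ccccc2OCCNCCOc2c(OC)cccc2OC)cc1` differs from compound 3 by one change: 4-ethoxyphenyl in place of 3-nitrophenyl on a saturated chain carbon bound to an oxygen on an aromatic ring. Every measured step touches this same benzyl group, and each was within the scatter: a number 0.01 log units higher from compound 1 to compound 2 (within the scatter), a number 0.17 log units higher from compound 1 to compound 3 (within the scatter) and a number 0.16 log units higher from compound 2 to compound 3 (within the scatter). Nothing here suggests that replacing one substituent on this ring with another shifts the number beyond the scatter, so for compound 4 an unchanged value is expected, with a step of a number 0.13 log units lower from compound 3 to compound 4 (within the scatter). Compound 4 is estimated at 9.15, in a range from 8.6 to 9.7.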

Compound 4, negative logarithm of the antagonist equilibrium constant: 9.11
Beside the measured number, compound 4's estimate is 0.04 log units above it; the range from low to high includes it.
By their numbers in this assay, from the lowest: compounds 1, 4, 2 and 3 (each within the scatter of the next).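

The step to the 4-ethoxyphenyl compound reads (a number 0.17 log units lower from compound 3 to compound 4 (within the scatter)), and the steps from the other two compounds read (a number 0.01 log units lower from compound 2 to compound 4 (within the scatter)) and (no change at the digits printed from compound 1 to compound 4 (within the scatter)). An ether on this ring therefore stands level with chloro, methyl and nitro, and none of the four compounds separates from the others. Nothing measured here explains why these different groups read alike. As far as these compounds go, whether an amine, a carboxylic acid or a longer chain such as hexyloxy on this ring would move the number beyond the scatter remains open.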